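Styryl replacement on the biaryl sulfonamide acid series

The compounds below may be only part of what the source reports. "The series", "measured", "known", "first", "only" and "open" are said of these compounds alone.

Compound 3 `CCCCCCCCS(=O)(=O)Nc1ccc(-c2ccccc2Cl)cc1C(=O)O` gives 14400 nM in an assay on mitochondria (strain BALB/c) for inhibition of glycerol-3-phosphate acyltransferase 1, mitochondrial (Mus musculus), read by scintillation counting, with a stated time of 10 min (on this read-out lower numbers stand for stronger inhibition and higher numbers for weaker inhibition), the lowest number of the three, though compound 1 `CCCCCCCCS(=O)(=O)Nc1cc(-c2ccccc2Cl)ccc1C(=O)O` with 26900 nM sits within the scatter of it. Compound 2 `CCCCCCCCS(=O)(=O)Nc1cc(-c2ccccc2O)ccc1C(=O)O` gives 63100 nM, beyond the scatter from compound 3. Going by the values given here, the only single-point step in hand, a 2.3-fold higher number from compound 1 to compound 2 (0.37 log units; beyond the scatter), is modest and concerns hydroxy in place of chloro, not the whole group. Compound 4 `CCCCCCCCS(=O)(=O)Nc1ccc(/C=C/c2ccc(OC)cc2)cc1C(=O)O` differs from compound 3 by 2-(4-methoxyphenyl)ethenyl in place of 2-chlorophenyl on an aromatic carbon. Among the compounds with values here, no measured step exchanges the whole 2-chlorophenyl, so the step from compound 1 to compound 2 gives only weak guidance; a change of this extent could move the number either way, and no direction beyond the scatter is expected. The estimate for compound 4 is 15000 nM in this assay, range 4000 nM to 60000 nM, meaning an expected 1.0-fold higher number from compound 3 to compound 4 (0.02 log units; within the scatter).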

Compound 4, half-maximal inhibitory concentration: 37100 nM
Estimate against measurement, compound 4: 2.5-fold (0.39 log units) below; the range from low to high includes it.
By their numbers in this assay, from the lowest: compounds 3, 1, 4 and 2 (each within the scatter of the next, the first and the last beyond it).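

In this assay the exchange of 2-chlorophenyl for 2-(4-methoxyphenyl)ethenyl, on the aromatic carbon meta to a carboxy group and para to a large group, gives a 2.6-fold higher number from compound 3 to compound 4 (0.41 log units; beyond the scatter) and so a modest but real weakening. This position thus takes an exchange of the whole group, with a double bond outside the aromatic ring, at a modest cost, which the hydroxy for chloro step could not show.

Going by these compounds, whether the weakening follows the ethenyl link or the methoxy stays open, as does the effect of an amine in place of that methoxy. Nothing measured on these compounds bears on a cause for the step.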